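Phenyl on the hydroxymethyl carbon of compound 2

The source may report more compounds than this note shows. Statements on the series, on what has been measured and on what is new or still open speak of the compounds shown alone.

Compound 1 `CC(C)(C)C1=C(C(=O)O)N2C(=O)[C@H](CO)[C@H]2O1` and compound 2 `CC(C)(C)C1=C(C(=O)O)N2C(=O)[C@H](CO)[C@@H]2O1` share one core and differ only in configuration. In an ADME assay, in phosphate buffer, at 28 degrees C, at pH 7.0 (a lower number here means that the compound disappears faster, a higher number that the compound lasts longer), compound 1 gives 5 h. Going by the values given here, compound 2 gives 2.4 h, the lower of the two numbers so far, and the step of a 2.1-fold lower number from compound 1 to compound 2 (0.32 log units; beyond the scatter) rests on the fact that compounds 1 and 2 differ only in the configuration as drawn alone. Compound 3 `CC(C)(C)C1=C(C(=O)O)N2C(=O)[C@H]([C@H](O)c3ccccc3)[C@@H]2O1` has not yet been measured in this assay. It differs from compound 2 by phenyl in place of hydrogen on a saturated chain carbon bound to an oxygen on a saturated carbon and a saturated ring carbon. Among the compounds with values here, no measured step adds a group anywhere: the single step so far, a 2.1-fold lower number from compound 1 to compound 2 (0.32 log units; beyond the scatter), is a change of configuration and carries no information about a phenyl at this place. The half-life of compound 3 is therefore expected near that of compound 2, with no change at the digits printed from compound 2 to compound 3 (within the scatter) expected to remain within the scatter. The estimate for compound 3 is 2.4 h, within 1.2 h to 5 h.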

Compound 3, half-life: 0.5 h
The estimate for compound 3 lay 4.8-fold (0.68 log units) above the measured number; measured number outside the range, below it.
By their numbers in this assay, from the lowest: compound 3; then compound 2; then compound 1.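

Phenyl in place of hydrogen on the saturated chain carbon bound to an oxygen on a saturated carbon and a saturated ring carbon gives a 4.8-fold lower number from compound 2 to compound 3 (0.68 log units; beyond the scatter) in this assay. Going by these compounds alone, this is the first measured change of a group, and it shows that the half-life responds to substitution at this place, which the earlier change of configuration could not show. Nothing at hand on these compounds accounts for the size or direction of this step.

Open, from the compounds shown here alone, is whether the shorter half-life is tied to phenyl or would also follow from a methyl or a cyclohexyl at this place. Also open, going by these compounds, is how phenyl would read on the core with the configuration of compound 1, or with the opposite configuration at the carbon that carries it.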